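Cytotoxicity notes on the shared-core series

The source may report more compounds than this note shows. Statements on the series, on what has been measured and on what is new or still open speak of the compounds shown alone.

Compound 1 `Fc1cccc(F)c1Cn1ccc2nc(-c3c(F)cccc3F)nc-2c1`, compound 2 `Cc1ccn(Cc2c(F)cccc2F)c2nc(-c3c(F)cccc3F)nc1-2` and compound 3 `COc1ccccc1Cn1ccc2nc(-c3ccccc3)nc-2c1` carry one shared core and were tested in an ADME assay on MDBK cells (Bos taurus) for cytotoxicity; on this read-out higher numbers stand for lower toxicity in this test and lower numbers for higher toxicity in this test. For compound 1 the result is a limit of the assay, > 100000 nM. For compound 2 the result is likewise a limit, > 100000 nM. Compound 3 also gives only a limit in this assay, > 100000 nM. Among the measured compounds shown here, compound 3 thus stands where every value so far stands: the limit of > 100000 nM in this assay, at which 3 of the 3 values shown sit. Compound 4 `c1ccc(CCCn2ccc3nc(-c4ccccc4)nc-3c2)cc1` is not yet measured; it differs from compound 3 by phenethyl in place of 2-methoxyphenyl on a saturated chain carbon bound to an aromatic nitrogen. For the measured compounds named here, no step between measured compounds is available, so the change is expected to give no step beyond the scatter, a number no higher from compound 3 to compound 4 (the limit leaves the size open). Compound 4 is therefore estimated at 100000 nM, between 50000 nM and 200000 nM, most likely reported again as a limit.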

Compound 4, half-maximal cytotoxic concentration: > 100000 nM
Compound 4: a limit, no number; the forecaster's own chance of this, stated with the estimate: 80%; the middle value lies on the limit itself.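

The step from compound 3 to compound 4 cannot be read, since both results are limits and not numbers: the limit of > 100000 nM in this assay, at which 4 of the 4 values shown sit.

The compounds shown leave open what actual number any of these four compounds would give in this assay, and whether any change on the shared core would move it.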